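This account rests on a few compounds, and the source may have more. Where it says the series, first, only, none or still open, it means among the compounds named here.

In a functional assay on MDA-MB-231 cells (Homo sapiens) for antiproliferative activity, read by MTT assay, with a stated time of 48 h (a lower number here means a stronger inhibitor, a higher number a weaker inhibitor), compound 3 `COc1ccc(-n2cc(COC(=O)/C(C)=C/CC/C(C)=C/CC/C(C)=C/CC[C@@H]3[C@@]4(C)CCC(=O)C(C)(C)[C@H]4CC[C@@]3(C)O)nn2)cc1` gives > 150000 nM, which is a limit of the assay and not a number. Compound 1 `C/C(=C\CC/C(C)=C/CC[C@@H]1[C@@]2(C)CCC(=O)C(C)(C)[C@H]2CC[C@@]1(C)O)CC/C=C(\C)C(=O)OCc1cn(-c2ccccc2Br)nn1` gives > 150000 nM, which is also a limit. Compound 2 `C#CCOC(=O)/C(C)=C/CC/C(C)=C/CC/C(C)=C/CC[C@@H]1[C@@]2(C)CCC(=O)C(C)(C)[C@H]2CC[C@@]1(C)O` gives a true number, 114000 nM.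

Compound 4 `C/C(=C\CC/C(C)=C/CC[C@@H]1[C@@]2(C)CCC(=O)C(C)(C)[C@H]2CC[C@@]1(C)O)CC/C=C(\C)C(=O)OCc1cn(-c2cccc(Cl)c2)nn1` differs from compound 3 in one group, with 3-chlorophenyl in place of 4-methoxyphenyl on an aromatic nitrogen.

The nearest measured change is on that same nitrogen, where 4-methoxyphenyl replaces 2-bromophenyl, and it gives a step that the two limits leave unreadable from compound 1 to compound 3. The other measured change, with ethynyl in place of 1-(2-bromophenyl)-1H-1,2,3-triazol-4-yl, gives an at least 1.3-fold lower number from compound 1 to compound 2 (0.11 log units; that floor lies within the scatter). Within the data shown here, the series so far is dominated by the limit of > 150000 nM in this assay, at which 2 of the 3 values shown sit.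

Given a step that the two limits leave unreadable from compound 1 to compound 3, no step beyond the scatter and no particular direction is expected in this assay. The expected outcome is a number no higher from compound 3 to compound 4 (the limit leaves the size open). For compound 4 the estimated value is 150000 nM, with an expected range from 80000 nM to 300000 nM.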

Compound 4, half-maximal inhibitory concentration: 103000 nM
Compound 4: the middle estimate sits 1.5-fold (0.16 log units) above what was measured; the range from low to high includes it.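

In this assay, compound 4 is the first compound shown with an aryl group on the aromatic nitrogen of the five-membered ring that gives a true number and not a limit. Yet that change of aryl group cannot be said to matter, since the readable floors are small: an at least 1.4-fold lower number from compound 3 to compound 4 (0.16 log units; that floor lies within the scatter), and an at least 1.4-fold lower number from compound 1 to compound 4 (0.16 log units; that floor lies within the scatter). The whole aryl-bearing ring in place of ethynyl likewise gives only a 1.1-fold lower number from compound 2 to compound 4 (0.04 log units; within the scatter), so on this evidence, carrying 3-chlorophenyl on that ring leaves the number where the ethynyl compound stands.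

On these data alone, the true sizes of the steps from compound 1 and compound 3 stay open because these two compounds give only limits: the limit of > 150000 nM in this assay, at which 2 of the 4 values shown sit. Also open is whether a 4-aminophenyl group or a carboxylic acid on that aromatic nitrogen would shift the number beyond the scatter.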